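The source may hold more compounds than are shown below. What is called first, only, known or untested is meant among the compounds shown, and "the series" means these compounds.

In a functional assay on PC-3 cells (Homo sapiens) for inhibition, read by MTT assay, with stated times of 18 h and 4 h (on this read-out higher numbers stand for weaker inhibition and lower numbers for stronger inhibition), compound 1 `CCCCCCCCCCCCCCCCOP(=O)(O)OCCSC(=S)N1CCCCCC1` gives 32100 nM and compound 2 `CCCCCCCCOP(=O)(O)OCCSC(=S)N1CCCCCC1` gives 56800 nM. Going by the values given here, these are the only two measurements so far, and they sit within the scatter of each other, so neither can be ranked firmly above the other. Compound 3 `CCCOP(=O)(O)OCCSC(=S)N1CCCCCC1` has not yet been measured. It differs from compound 2 as follows: hydrogen in place of pentyl on a saturated chain carbon, three bonds along the chain from an oxygen on an unsaturated carbon. In words, this is hydrogen in place of pentyl on a saturated chain carbon, three bonds along the chain from an oxygen on an unsaturated carbon, which turns octyl into propyl. Among the compounds with values here, the closest precedent is the one measured step, also a cut in the saturated chain: a 1.8-fold higher number from compound 1 to compound 2 (0.25 log units; within the scatter). A single step inside the scatter is thin evidence, but it gives a tentative direction, toward a higher number and so weaker inhibition. On that basis, the expected step is a 1.5-fold higher number from compound 2 to compound 3 (0.18 log units; within the scatter), a modest change that may not clear the scatter. The estimated value for compound 3 is 85000 nM, with an expected range of 40000 nM to 200000 nM.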

Compound 3, half-maximal inhibitory concentration: > 100000 nM
Compound 3: no number, only a limit; the forecaster's own chance of this, stated with the estimate: 25%; at least 1.1-fold (0.07 log units) between middle value and limit.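

Compound 3 gives a limit of the assay and not a number in this assay: the limit of > 100000 nM in this assay, at which 1 of the 3 values shown sits.

Shortening octyl to propyl gives an at least 1.7-fold higher number from compound 2 to compound 3 (0.24 log units; that floor lies within the scatter), so only a floor for this step is known, and the real step could be larger or could stay close to that floor. Going by these compounds alone, the earlier pair showed only that compound 1, with the longer chain, and compound 2 could not be told apart, whereas this shorter chain is the first at this place to give no measurable number and shows no sign of stronger inhibition than octyl.

The compounds shown leave open how far the true value of compound 3 lies past its limit, so the size of the loss, if there is one, remains unknown. They also leave open how a pentyl chain would behave at this place, and whether a chain ending in an amine or a carboxylic acid would give a readable number in this assay.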